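The source may report more compounds than this note shows. Statements on the series, on what has been measured and on what is new or still open speak of the compounds shown alone.

In a functional assay on HCT-116 cells (Homo sapiens) for inhibition, read by colorimetric assay, with a stated time of 3 days (a lower number here means a stronger inhibitor, a higher number a weaker inhibitor), compound 1 `NC(=O)C(=O)NCCCCCC(=O)Nc1ccccc1` is recorded only as a limit, > 100000 nM. Among the compounds with values here, compound 2 `CC(C)(C)C(O)(O)C(=O)NCCCCCC(=O)Nc1ccccc1` gives 54400 nM, the only true number so far. Within the data shown here, the single measured step, an at least 1.8-fold lower number from compound 1 to compound 2 (0.26 log units; that floor lies within the scatter), rests on (the limit of > 100000 nM in this assay, at which 1 of the 2 values shown sits), so its size stays uncertain. Compound 3 `O=C(CCCCCNC(=O)c1cc(=O)c(O)co1)Nc1ccccc1` changes the group on the same carbonyl carbon: a group of 8 heavy atoms (5 carbon, 3 oxygen; one six-membered aromatic ring with 1 hetero atom) in place of a group of 7 heavy atoms (5 carbon, 2 oxygen; no ring), on a carbonyl carbon. Among the measured compounds shown here, no measured step brings in a ring at this place, so the expectation starts from compound 2 at 54400 nM. The expected change is a 1.6-fold lower number from compound 2 to compound 3 (0.19 log units; within the scatter), which would not be a clear step beyond the scatter. For compound 3 the estimated value is 35000 nM, with an expected range of 8000 nM to 100000 nM.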

Compound 3, half-maximal inhibitory concentration: > 100000 nM
Compound 3 gave a limit, no number (the forecaster's own chance of this, stated with the estimate: 20%); middle value at least 2.8-fold (0.45 log units) from the limit.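

A ring on this carbonyl carbon, the first among these compounds, gives no true number: in this assay compound 3 is recorded only as a limit (> 100000 nM). Replacing 1,1-dihydroxy-2,2-dimethylpropyl with this ring gives an at least 1.8-fold higher number from compound 2 to compound 3 (0.26 log units; that floor lies within the scatter) and the real change could be small or large. The step between the two limits cannot be read, and most of this series stays unresolved: the limit of > 100000 nM in this assay, at which 2 of the 3 values shown sit. From the compounds shown here alone, whether an amine or a carboxylic acid at this place would give a clear number stays open. So does the effect of a longer chain in the shared core.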